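Sulfonamide extension on the ether chain of compound 2

This account rests on a few compounds, and the source may have more. Where it says the series, first, only, none or still open, it means among the compounds named here.

Measured so far in a functional assay on PANC-1 cells (Homo sapiens) for inhibition, read by MTT assay, with a stated time of 24 h, tested at 10 uM; a lower number here means less inhibition, a higher number more inhibition at the concentration tested (going by the name of the read-out):
compound 1 `CCOc1cc(=O)n(CCCO)c2c1CC(CC=C(C)C)C(C)(C)C2` gives 66.5%
compound 2 `CCOc1cc(=O)n(CCCO)c2c1CC(C/C=C(\C)CCC=C(C)C)C(C)(C)C2` gives 67.8%
compound 3 `CC(C)=CCC/C(C)=C/CC1Cc2c(OCC=C(C)C)cc(=O)n(CCCO)c2CC1(C)C` gives 30.3%

Compound 2 holds the highest number of the three, but compound 1 sits within the scatter of it (a number 1.3 percentage points higher from compound 1 to compound 2 (within the scatter)), while compound 3 lies clearly lower (a number 37.5 percentage points lower from compound 2 to compound 3 (beyond the scatter)). Compound 4 `CC(C)=CCC/C(C)=C/CC1Cc2c(OCCCNS(=O)(=O)c3ccc(Br)cc3)cc(=O)n(CCCO)c2CC1(C)C` is compound 2 with (((4-bromophenyl)sulfonyl)amino)methyl in place of hydrogen on a saturated chain carbon, two bonds along the chain from an oxygen on an aromatic ring. Among the compounds with values here, of the measured steps, only the one from compound 2 to compound 3 touches the chain bound to the aromatic oxygen, and it was large and downward; the step from compound 1 to compound 2 altered another place and stayed within the scatter. A downward step beyond the scatter in this assay is therefore expected for compound 4, its size uncertain. Compound 4 is estimated at 45%, between 20% and 68%, meaning an expected step of a number 22.8 percentage points lower from compound 2 to compound 4 (beyond the scatter).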

Compound 4, a percentage reported as inhibition, at one concentration (the size of the read-out at that concentration, not a potency): 15.2%
Estimate against measurement, compound 4: 29.8 percentage points above; the measured number lies below the stated range.
By their numbers in this assay, from the lowest: compound 4; then compound 3; then compounds 1 and 2 (each within the scatter of the next).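

In this assay, the sulfonamide extension gives a number 52.6 percentage points lower from compound 2 to compound 4 (beyond the scatter), so a second, quite different change on the chain bound to the aromatic oxygen also brings a large downward step. Across compound 3 and compound 4, no change at this position keeps the number of compound 2, and neither compound goes against that. Nothing measured bears on the reason for this drop.

Going by these compounds, whether the loss follows the bromophenyl sulfonyl part or the added chain itself stays open. A primary amine or a carboxylic acid at the end of the ether chain could separate the two.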